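Swapping phenyl for cyclopropyl on a urea nitrogen

This account rests on a few compounds, and the source may have more. Where it says the series, first, only, none or still open, it means among the compounds named here.

Compound 1 `O=C(Nc1ccccc1)Nc1ccc(-c2nc(N3CC4CCC(C3)O4)c3cnn(C4CCC5(CC4)OCCO5)c3n2)cc1`: in an in vitro ADME assay on microsomes (Mus musculus) for metabolic stability (on this read-out lower numbers stand for a shorter-lived compound and higher numbers for a longer-lived compound), compound 1 gives > 0.5 h, a limit of the assay.
Compound 2 `CCn1ncc2c(N3CC4CCC(C3)O4)nc(-c3ccc(NC(=O)NC)cc3)nc21`: in this assay compound 2 gives > 0.5 h, a limit of the assay.
Compound 3 `CNC(=O)Nc1ccc(-c2nc(N3CC4CCC(C3)O4)c3cnn(C(C)C)c3n2)cc1`: in this assay compound 3 gives > 0.5 h, a limit of the assay.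

Compound 1 therefore stands at the limit of > 0.5 h in this assay, at which 3 of the 3 values shown sit, as do the other two. Compound 4 `O=C(Nc1ccc(-c2nc(N3CC4CCC(C3)O4)c3cnn(C4CCC5(CC4)OCCO5)c3n2)cc1)NC1CC1` differs from compound 1 by cyclopropyl in place of phenyl on an amide-type nitrogen. Among the compounds with values here, the one measured step on a shared scaffold, a step that the two limits leave unreadable from compound 2 to compound 3, concerns a different part of the molecule, and its size cannot be read because both values are limits. Within the data shown here, no measured step bears on the change from compound 1 to compound 4, so no direction beyond the scatter is expected in this assay. Compound 4 is estimated at 1 h, with a range from 0.4 h to 3 h. The step that the limit leaves unreadable from compound 1 to compound 4 is expected to be small, and the result is likely to come out again as a limit.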

Compound 4, half-life: 0.417 h
Estimate against measurement, compound 4: 2.4-fold (0.38 log units) above; the measured number falls inside the stated range.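

In this assay, cyclopropyl in place of phenyl on an amide-type nitrogen gives an at least 1.1-fold lower number from compound 1 to compound 4 (0.07 log units; that floor lies within the scatter). The true size of this step stays hidden, since compound 1 sits at a limit, so the phenyl group can be swapped here without any drop beyond the scatter being shown. Within the data shown here, compound 4 is the only compound with a real number rather than a limit: the limit of > 0.5 h in this assay, at which 3 of the 4 values shown sit.

From the compounds shown here alone, how a pyridine ring or a cyclohexyl ring on this nitrogen would behave stays open. So does whether the lower number of compound 4 would hold on repeat measurement.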